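The compounds below may be only part of what the source reports. "The series", "measured", "known", "first", "only" and "open" are said of these compounds alone.

Compound 2 `CC1CCN(C2CCN(S(=O)(=O)c3cccnc3Cl)CC2)CC1` gives, in a functional assay on DLD-1 cells (Homo sapiens) for antiproliferative activity, read by CellTiter-Glo, with a stated time of 72 h (a higher number here means a weaker inhibitor, a lower number a stronger inhibitor), only a limit of > 5000 nM rather than a number. That result is a limit, (the limit of > 5000 nM in this assay, at which 1 of the 3 values shown sits), so compound 2 cannot be placed on the scale beside the numbered compounds. Two relatives do carry numbers: compound 3 `CC1CCN(C2CCN(S(=O)(=O)c3ccccc3-c3ccccc3)CC2)CC1` gives 0.96 nM in this assay, and compound 1 `Cc1ccc(-c2ccccc2S(=O)(=O)N2CCC(N3CCC(C)CC3)CC2)cc1` gives 366 nM. Within the data shown here, the one measured step, a 380-fold lower number from compound 1 to compound 3 (2.58 log units; beyond the scatter), concerns hydrogen in place of methyl on an aromatic carbon and does not touch the part of the molecule changed here.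

Compound 4 `CC1CCN(C2CCN(S(=O)(=O)c3cc(Cl)cc(Cl)c3)CC2)CC1` differs from compound 2 in one place: 3,5-dichlorophenyl in place of 2-chloropyridin-3-yl on a sulfonyl sulfur. Among the measured compounds shown here, no measured step speaks to this exchange, and the starting point is a limit, so the expectation is loose. Compound 4 is expected to give about 3000 nM in this assay, with a range from 400 nM to 10000 nM. That estimate would mean a step of an at least 1.6-fold lower number from compound 2 to compound 4 (0.22 log units; that floor lies within the scatter), with a real chance that the assay again reports only a limit.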

Compound 4, half-maximal inhibitory concentration: 3400 nM
Beside the measured number, compound 4's estimate is 1.1-fold (0.05 log units) below it, within the range that was stated.
By their numbers in this assay, from the lowest: compound 3; then compound 1; then compound 4. At a limit, above all of these: compound 2.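

In this assay, 3,5-dichlorophenyl in place of 2-chloropyridin-3-yl on a sulfonyl sulfur turns a limit into a real number, and the step reads an at least 1.4-fold lower number from compound 2 to compound 4 (0.16 log units; that floor lies within the scatter), so no true gain can be claimed from the floor alone. Compound 2 stands at a limit, so the real size of this step cannot be read: the limit of > 5000 nM in this assay, at which 1 of the 4 values shown sits. Compound 3 gives 0.96 nM and compound 4 gives 3400 nM, so the group on the sulfonyl sulfur can move the result a long way even with the rest of the molecule unchanged.

The exchange removes the ring nitrogen and adds a second chlorine in one step, and the compounds shown do not separate those two changes. From the compounds shown here alone, how a phenyl ring carrying a single chlorine, an amine or a carboxylic acid would behave on the sulfonyl sulfur remains open.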